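This account rests on a few compounds, and the source may have more. Where it says the series, first, only, none or still open, it means among the compounds named here.

Measured compounds in a functional assay on 143B cells (Homo sapiens) for inhibition, read by MTT assay, with a stated time of 72 h; on this read-out lower numbers stand for stronger inhibition and higher numbers for weaker inhibition:
- compound 1 `O=C(CCC(=O)OCCCCCCSc1ccc([N+](=O)[O-])c2nonc12)Nc1ccccc1F`, 3030 nM
- compound 2 `O=C(CCC(=O)OCCCCCCSc1ccc([N+](=O)[O-])c2nonc12)Nc1cccc(Cl)c1`, 2890 nM
- compound 3 `CN(C)CCCNC(=O)CCC(=O)OCCCCCCSc1ccc([N+](=O)[O-])c2nonc12`, 1180 nM

Compound 2 holds the second highest of the three numbers in this assay. Its nearest neighbour is compound 1, where the step of a 1.0-fold lower number from compound 1 to compound 2 (0.02 log units; within the scatter) lies within the scatter, so the two stand level; the furthest is compound 3, reached through a 2.4-fold lower number from compound 2 to compound 3 (0.39 log units; beyond the scatter), beyond the scatter.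

The next compound, compound 4 `O=C(CCC(=O)OCCCCCCSc1ccc([N+](=O)[O-])c2nonc12)NCCN1CCCC1`, has not yet been measured in this assay. It differs from compound 2 in one place: 2-(pyrrolidin-1-yl)ethyl in place of 3-chlorophenyl on an amide-type nitrogen.

Among the compounds with values here, the steps that bear on this change are the two in which an amine-bearing chain replaces an aryl group on the amide-type nitrogen: a 2.4-fold lower number from compound 2 to compound 3 (0.39 log units; beyond the scatter) and a 2.6-fold lower number from compound 1 to compound 3 (0.41 log units; beyond the scatter), both modest and both beyond the scatter, in the same direction. The group entering in compound 4 is likewise a chain carrying a nitrogen, though a different one from that in compound 3, so the same direction and a comparable size of step are expected, with wider uncertainty than a repeat measurement.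

Compound 4 is therefore expected to give about 1300 nM in this assay, within 600 nM to 3000 nM. This estimate means a step of a 2.2-fold lower number from compound 2 to compound 4 (0.35 log units; beyond the scatter), expected to lie close to a 2.4-fold lower number from compound 2 to compound 3 (0.39 log units; beyond the scatter).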

Compound 4, half-maximal inhibitory concentration: 5580 nM
For compound 4 the middle estimate is 4.3-fold (0.63 log units) below the measured one, and the stated range ends below it.
By their numbers in this assay, from the lowest: compound 3; then compounds 2, 1 and 4 (each within the scatter of the next).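

In this assay an amine-bearing chain on the amide-type nitrogen does not by itself set a compound apart from the aryl amides: a 1.9-fold higher number from compound 2 to compound 4 (0.29 log units; within the scatter) and a 1.8-fold higher number from compound 1 to compound 4 (0.27 log units; within the scatter) both stay within the scatter, so compound 4 stands level with compound 2 and compound 1. Within the data shown here, the separation lies between the two amine chains instead, with a 4.7-fold higher number from compound 3 to compound 4 (0.67 log units; beyond the scatter) as a step beyond the scatter, so the earlier steps from the aryl amides to compound 3 hold for the 3-(dimethylamino)propyl group and do not extend to amine chains in general, compound 4 being the case against. No measurement on hand bears on the reason for this gap.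

The change from compound 3 to compound 4 alters both the chain and its terminal amine, so a 2-(dimethylamino)ethyl or a 3-(pyrrolidin-1-yl)propyl group on the same nitrogen would be needed to separate the two. From the compounds shown here alone, how a piperidine, a morpholine or a primary amine at the end of the chain would read also stays open.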